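A few compounds are considered here, and "the series" means these few. Any claim that something is new, unique, unknown or untested is made for them only; others in the source may bear on it.

In an ADME assay on HEK293 cells (Homo sapiens) for cytotoxicity, read by CCK-8 assay, with a stated time of 48 h (on this read-out higher numbers stand for weaker inhibition and lower numbers for stronger inhibition), compound 2 `COc1ccc(/C=C\c2cc(OC)c(OC)c(OC)c2)cc1OCc1ccc(CN2CC[C@H](O)C2)cc1` gives > 50000 nM, which is a limit of the assay and not a number. Compound 1 `COc1ccc(/C=C\c2cc(OC)c(OC)c(OC)c2)cc1OCc1ccc(CN2CCCC[C@@H]2C(=O)O)cc1`, which carries 2-carboxypiperidin-1-yl on a saturated chain carbon bound to an aromatic carbon, gives 42000 nM. Compound 3 `COc1ccc(/C=C\c2cc(OC)c(OC)c(OC)c2)cc1OCc1ccc(CN2CC[C@@H](C(=O)O)C2)cc1` has not yet been measured. It has 3-carboxypyrrolidin-1-yl in place of the 3-hydroxypyrrolidin-1-yl of compound 2, and the counted difference is 3-carboxypyrrolidin-1-yl in place of 3-hydroxypyrrolidin-1-yl on a saturated chain carbon bound to an aromatic carbon. Within the data shown here, only one measured step bears on this change: an at least 1.1-fold higher number from compound 1 to compound 2 (0.07 log units; that floor lies within the scatter). That step also exchanges a carboxy-bearing group for a hydroxy-bearing one, though in the opposite direction, and it stays within the scatter. No step beyond the scatter is therefore expected in this assay, and the estimated step is an at least 1.1-fold lower number from compound 2 to compound 3 (0.04 log units; that floor lies within the scatter). For compound 3 the expected value is 45000 nM, with an estimated range from 22000 nM to 90000 nM.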

Compound 3, half-maximal inhibitory concentration: 27000 nM
Compound 3: the middle estimate sits 1.7-fold (0.22 log units) above what was measured; the range from low to high includes it.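

In this assay, putting 3-carboxypyrrolidin-1-yl in place of 3-hydroxypyrrolidin-1-yl on a saturated chain carbon bound to an aromatic carbon gives an at least 1.8-fold lower number from compound 2 to compound 3 (0.26 log units; that floor lies within the scatter). That figure is only a floor, and the true size of the step cannot be read because compound 2 stands at a limit of the assay and not at a number: the limit of > 50000 nM in this assay, at which 1 of the 3 values shown sits. The two carboxy-bearing groups can be compared directly, and exchanging them gives a 1.6-fold lower number from compound 1 to compound 3 (0.19 log units; within the scatter), so 3-carboxypyrrolidin-1-yl and 2-carboxypiperidin-1-yl do not separate in this read-out.

As far as these compounds go, whether the change from the hydroxy-bearing group to the carboxy-bearing one truly goes beyond the scatter remains open. Also open, from the compounds shown here alone, is how a simple amine such as dimethylamino, or a morpholine ring, would read in this place.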